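Methyl to Isopropyl on the Phenyl Ring of Compound 3

The source may report more compounds than this note shows. Statements on the series, on what has been measured and on what is new or still open speak of the compounds shown alone.

compound 1 `CNC(=O)c1ccccc1Oc1nc(Nc2ccc(C(F)(F)F)cc2)ncc1Br`: > 50000 nM
compound 2 `CNC(=O)c1ccccc1Oc1nc(Nc2cccc(Br)c2)ncc1Br`: 31900 nM
compound 3 `CNC(=O)c1ccccc1Oc1nc(Nc2cccc(C)c2)ncc1Br`: 18600 nM
compound 4 `CNC(=O)c1ccccc1Oc1nc(Nc2cccc(C(C)C)c2)ncc1Br`: not yet measured

In a functional assay on MDA-MB-468 cells (Homo sapiens) for antiproliferative activity, read by MTT assay, with a stated time of 24 h (a higher number here means a weaker inhibitor, a lower number a stronger inhibitor), compound 1 gives only a limit, > 50000 nM, and sits at the limit of > 50000 nM in this assay, at which 1 of the 3 values shown sits. Compound 2 gives 31900 nM in this assay. Compound 3 gives 18600 nM in this assay, the lowest of the two numbers shown; the step of a 1.7-fold lower number from compound 2 to compound 3 (0.23 log units; within the scatter) is the only measured step, and since it lies within the scatter, compound 2 and compound 3 cannot be ordered against each other.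

Compound 4 differs from compound 3 by isopropyl in place of methyl on an aromatic carbon. Going by the values given here, no measured step concerns a change of this kind: the one step on record, a 1.7-fold lower number from compound 2 to compound 3 (0.23 log units; within the scatter), exchanges bromo for methyl at the same place and stays within the scatter. The two substituents compared there both sit where isopropyl now enters, so there is no measured basis for a move in either direction beyond the scatter in this assay.

Compound 4 is therefore expected to give about 16000 nM in this assay, within a range from 5000 nM to 50000 nM. That estimate corresponds to a step of a 1.2-fold lower number from compound 3 to compound 4 (0.07 log units; within the scatter), which is expected to remain within the scatter.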

Compound 4, half-maximal inhibitory concentration: 19500 nM
The estimate for compound 4 lay 1.2-fold (0.09 log units) below the measured number; measured number inside the range.
By their numbers in this assay, from the lowest: compounds 3, 4 and 2 (each within the scatter of the next). At a limit, above all of these: compound 1.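

In this assay, the larger group changes little: a 1.0-fold higher number from compound 3 to compound 4 (0.02 log units; within the scatter), and the comparison with the bromo compound gives a 1.6-fold lower number from compound 2 to compound 4 (0.21 log units; within the scatter). Before this result, only the exchange of bromo for methyl could be read at this place, on an aromatic carbon meta to a large group; isopropyl now adds a third substituent, and going from 1 heavy atom in methyl to 3 heavy atoms in isopropyl leaves the number within the scatter, so compound 2, compound 3 and compound 4 cannot be ordered against one another. No measurement shown here offers a reason for this flat result.

Still open, as far as these compounds go, is whether a group of a different kind at this place, such as an amine or a carboxylic acid, would move the number beyond the scatter. Also open, from the compounds shown here alone, is whether a longer chain, such as hexyl, or a ring, such as morpholine, would do so, or whether the number in this assay stays in the same range whatever stands at this place.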